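A chlorinated ester in place of a carboxylic acid chain

A few compounds are considered here, and "the series" means these few. Any claim that something is new, unique, unknown or untested is made for them only; others in the source may bear on it.

compound 1 (`CC(=O)O[C@H]1CC[C@]2(C)[C@H](CC[C@@](C)(O)[C@H]2CC[C@@H]2C(C)=CC[C@H]3[C@H](CC[C@]3(C)OC(C)=O)C2(C)C)OC1(C)C`): 39200 nM
compound 2 (`CC1=CC[C@H]2[C@H](CC[C@]2(C)O)C(C)(C)[C@@H]1CC[C@H]1[C@]2(C)CC[C@H](OC(=O)CCC(=O)O)C(C)(C)O[C@H]2CC[C@@]1(C)O`): > 50000 nM (a limit)

Compound 2 gives > 50000 nM in a functional assay on MCF7 cells (Homo sapiens) for antiproliferative activity, read by MTT assay, with a stated time of 72 h (a higher number here means a weaker inhibitor, a lower number a stronger inhibitor), and this is a limit of the assay, not a number. Compound 3 (`CC1=CC[C@H]2[C@H](CC[C@]2(C)O)C(C)(C)[C@@H]1CC[C@H]1[C@]2(C)CC[C@H](OC(=O)c3ccc(Cl)cc3)C(C)(C)O[C@H]2CC[C@@]1(C)O`) keeps the rest of compound 2 and changes one group, with 4-chlorophenyl in place of 2-carboxyethyl on a carbonyl carbon. Among the measured compounds shown here, no measured pair in this small set shows what a single such change does, so any expectation remains loose. For the measured compounds named here, the only number available is that of compound 1 at 39200 nM, which suggests that measurable activity is within reach in this assay, though only weakly. A modest move toward stronger inhibition is therefore expected, and the estimated step is an at least 1.6-fold lower number from compound 2 to compound 3 (0.22 log units; that floor lies within the scatter). For compound 3 the expected value is 30000 nM, with an estimated range from 12000 nM to 60000 nM.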

Compound 3, half-maximal inhibitory concentration: 24100 nM
Estimate against measurement, compound 3: 1.2-fold (0.10 log units) above; low and high end bracket the measured number.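

In this assay, among the compounds shown here, 4-chlorophenyl in place of 2-carboxyethyl on a carbonyl carbon gives the first single change that can be read at this position, an at least 2.0-fold lower number from compound 2 to compound 3 (0.31 log units; beyond the scatter). The step is a floor and not a full size, because compound 2 stands at a limit of the assay: the limit of > 50000 nM in this assay, at which 1 of the 3 values shown sits.

In this pair, a measurable number at this position does not depend on the carboxylic acid of the 2-carboxyethyl group, since compound 3 lacks it.

The compounds shown leave open whether the step comes from the chlorine, from the aromatic ring or simply from the loss of the acid. A plain phenyl, a pyridine or a longer alkyl chain on the same carbonyl carbon would separate these readings.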